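A Second Chloro on the Core of Compound 3

The source may report more compounds than this note shows. Statements on the series, on what has been measured and on what is new or still open speak of the compounds shown alone.

Among the three compounds measured so far, compound 3 `ClCc1ccccc1Cn1cnc2ncnc(Cl)c21` is the only one that gives a number in a functional assay on MOLT-4 cells (Homo sapiens) for cytotoxicity, read by sulforhodamine B assay, with a stated time of 48 h; on this read-out higher numbers stand for lower toxicity in this test and lower numbers for higher toxicity in this test: compound 3 shows 16600 nM. Compound 1 `ClCc1ccc(Cn2cnc3c(Cl)ncnc32)cc1` reaches only a limit of this assay, > 100000 nM. Compound 2 `ClCc1ccccc1Cn1cnc2c(Cl)ncnc21` likewise gives a limit of this assay, > 100000 nM. The picture is thus dominated by the limit of > 100000 nM in this assay, at which 2 of the 3 values shown sit, and compound 3 alone stands inside the measured range. Compound 4 `ClCc1ccccc1Cn1cnc2nc(Cl)nc(Cl)c21` has not yet been measured in this assay; it differs from compound 3 by chloro in place of hydrogen on an aromatic carbon, in short chloro in place of hydrogen on an aromatic carbon. For the measured compounds named here, no two measured compounds differ in only one place, so no measured step exists to calibrate this change. A modest move toward higher toxicity is expected, within or only slightly beyond the scatter, and the step is estimated as a 1.7-fold lower number from compound 3 to compound 4 (0.22 log units; within the scatter). Compound 4 is expected to give about 10000 nM in this assay, with a likely range from 3000 nM to 40000 nM.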

Compound 4, concentration lethal to 50% of the cells: 7940 nM
The estimate for compound 4 lay 1.3-fold (0.10 log units) above the measured number; low and high end bracket the measured number.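

In this assay, for the compounds shown here, chloro in place of hydrogen on an aromatic carbon gives a 2.1-fold lower number from compound 3 to compound 4 (0.32 log units; beyond the scatter), the first measured step in this set, modest in size but beyond the usual scatter. It shows that this position, on the six-membered aromatic ring with 2 nitrogen and between two ring nitrogen atoms, can carry a chloro while the number stays inside the measured range and moves toward higher toxicity in this test. The earlier compounds could not show this, because none of them formed a pair differing in one place and much of the set gives no number: the limit of > 100000 nM in this assay, at which 2 of the 4 values shown sit.

This single step leaves open whether the shift belongs to chloro itself, which an amine or a methoxy group on the same aromatic carbon would test. It also leaves open whether the same change would act alike on the other compounds shown.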